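The source may report more compounds than this note shows. Statements on the series, on what has been measured and on what is new or still open speak of the compounds shown alone.

Of the compounds shown here, two have so far been measured in an assay on isolated protein for inhibition of P2X purinoceptor 7 (Homo sapiens); on this read-out lower numbers stand for stronger inhibition and higher numbers for weaker inhibition. Compound 1, `CN(C(=O)c1cc(Cl)c(=O)n(Cc2c(Cl)cccc2Cl)c1)c1ccccc1`, gives 126 nM in this assay. Compound 2, `CCN1CCC[C@H]1C(=O)NCc1ccc(F)cc1Cl`, is built on a different core and is the starting point of the step followed here. For compound 2 this assay reports only a limit, < 1000 nM, and not a number. That is where compound 2 stands: the limit of < 1000 nM in this assay, at which 1 of the 2 values shown sits, so no more than this bound is known of it, and the gap between compound 1 and compound 2 cannot be sized.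

Compound 3, `CC(=O)N1CCC[C@H]1C(=O)NCc1ccc(F)cc1Cl`, is drawn from compound 2 by one change: acetyl in place of ethyl on an amine nitrogen in a ring. Going by the values given here, no measured pair shows this change in this assay, so its effect is open. The step from compound 2 to compound 3 is expected to be a step that the limit leaves unreadable from compound 2 to compound 3, most likely small and within the usual scatter, with no direction favoured. Compound 3 is therefore estimated at 800 nM, with a range from 150 nM to 4000 nM.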

Compound 3, half-maximal inhibitory concentration: 100 nM
For compound 3 the middle estimate is 8.0-fold (0.90 log units) above the measured one; the measured number lies below the stated range.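

The step from compound 2 to compound 3 cannot be read in this assay, because compound 2 carries only a limit and not a number: the limit of < 1000 nM in this assay, at which 1 of the 3 values shown sits.

The compounds shown leave open how large the effect of acetyl in place of ethyl on an amine nitrogen in a ring is, and in which direction it runs.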